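This account rests on a few compounds, and the source may have more. Where it says the series, first, only, none or still open, it means among the compounds named here.

Two compounds of the series have been run in a functional assay on HCT-116 cells (Homo sapiens), read by MTT assay, with a stated time of 72 h; on this read-out higher numbers stand for weaker inhibition and lower numbers for stronger inhibition. Compound 1 `Nc1nc(N)c2c(-c3ccccc3)cn([C@@H]3O[C@H](CO)[C@@H](O)[C@H]3O)c2n1` carries two amino groups on the core. In this assay compound 1 reaches only the limit of the assay, > 20000 nM. Compound 2 `Cc1nc(N)c2c(-c3ccoc3)cn([C@@H]3O[C@H](CO)[C@@H](O)[C@H]3O)c2n1` differs from compound 1 at two places, one of them a methyl in place of an amino on the core. In this assay compound 2 likewise gives only a limit, > 20000 nM. Compound 2 therefore stands at the edge of what the assay reports, together with compound 1; (the limit of > 20000 nM in this assay, at which 2 of the 2 values shown sit), so no ordering between the two can be read. Within the data shown here, no pair of measured compounds differs in a single place, so no measured step exists.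

Compound 3 `Nc1nc(N)c2c(-c3ccoc3)cn([C@@H]3O[C@H](CO)[C@@H](O)[C@H]3O)c2n1` has yet to be run. It differs from compound 2 by amino in place of methyl on an aromatic carbon, which brings back the two amino groups of compound 1 on the core. With both measured compounds sitting at the limit, the step of a number no higher from compound 2 to compound 3 (the limit leaves the size open) is expected to stay within the scatter, in no fixed direction. Compound 3 is accordingly expected at 20000 nM, with a range from 8000 nM to 50000 nM, and most likely reported again only as a limit.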

Compound 3, half-maximal inhibitory concentration: > 20000 nM
Compound 3 was reported as a limit; the forecaster's own chance of this, stated with the estimate: 80%; the middle value sits exactly at the limit.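

No new step can be read: compound 1, compound 2 and compound 3 are all reported only as limits, so neither change leading to compound 3 has a readable size: the limit of > 20000 nM in this assay, at which 3 of the 3 values shown sit.

The compounds shown leave open whether amino against methyl, or furan-3-yl against phenyl, on the shared core alters inhibition in this assay.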